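Replacing 4-bromophenyl with 3-nitrophenyl on a shared core

This account rests on a few compounds, and the source may have more. Where it says the series, first, only, none or still open, it means among the compounds named here.

Compound 1 `COc1cc(-c2cc(-c3ccc(Cl)cc3)nc(-c3ccccc3)n2)cc(OC)c1OC` gives 6230 nM
Compound 2 `COc1cc(-c2cc(-c3ccc(Br)cc3)nc(-c3ccccc3)n2)cc(OC)c1OC` gives 3170 nM

For the measured compounds named here, only these two numbers are available from a functional assay on HT-29 cells (Homo sapiens) for inhibition, read by MTT assay, with a stated time of 48 h (on this read-out lower numbers stand for stronger inhibition and higher numbers for weaker inhibition), and the one measured step is a 2.0-fold lower number from compound 1 to compound 2 (0.29 log units; within the scatter). Going by the values given here, neither number stands clear of the other, so compound 2 sits level with the only other compound measured.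

Compound 3 `COc1cc(-c2cc(-c3cccc([N+](=O)[O-])c3)nc(-c3ccccc3)n2)cc(OC)c1OC` differs from compound 2 in a larger way: 3-nitrophenyl in place of 4-bromophenyl on an aromatic carbon. In short, 3-nitrophenyl takes the place of 4-bromophenyl on an aromatic carbon next to the ring nitrogen. Among the compounds with values here, the halogen step is the only measured evidence, and it bears on this change only in part. Within the data shown here, it exchanged one halogen on the same phenyl ring, whereas no measured compound carries 3-nitrophenyl. A step that stays within the scatter offers no direction to carry forward, so no shift beyond the scatter is expected in this assay. The expected step is a 1.3-fold higher number from compound 2 to compound 3 (0.10 log units; within the scatter), an estimate held with little confidence. For compound 3 the estimated value is 4000 nM, with an expected range from 1200 nM to 14000 nM.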

Compound 3, half-maximal inhibitory concentration: > 25000 nM
Compound 3: a limit, no number; the forecaster's own chance of this, stated with the estimate: 5%; middle value at least 6.2-fold (0.79 log units) from the limit.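

In this assay, compound 3 gives only a limit and no number (> 25000 nM). The halogen exchange on the phenyl ring had stayed within the scatter (a 2.0-fold lower number from compound 1 to compound 2 (0.29 log units; within the scatter)), but replacing the whole aryl group on this aromatic carbon next to the ring nitrogen moves the read-out beyond it in both available comparisons (an at least 7.8-fold higher number from compound 2 to compound 3 (0.89 log units; beyond the scatter)) (an at least 4.0-fold higher number from compound 1 to compound 3 (0.60 log units; beyond the scatter)). For the compounds shown here, this is the first sign that the group at this position can matter to the read-out, though the full size of both steps cannot be read, and the series now has one compound at the limit and two with numbers: (the limit of > 25000 nM in this assay, at which 1 of the 3 values shown sits).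

The change from 4-bromophenyl to 3-nitrophenyl alters both the group on the phenyl ring and its place on that ring, so the compounds shown do not separate the contribution of the nitro group from that of its placement. They also leave open how an amine or a carboxylic acid on the same phenyl ring would read out, and whether any such group could bring the number back toward those of the two halogen compounds.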